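Sulfonyl Piperidine Amides: A Series Sitting at the Limit

A few compounds are considered here, and "the series" means these few. Any claim that something is new, unique, unknown or untested is made for them only; others in the source may bear on it.

Three compounds built on the shared core were tested in a functional assay on MIA PaCa-2 cells (Homo sapiens) for inhibition, read by MTT assay, with a stated time of 3 days; on this read-out higher numbers stand for weaker inhibition and lower numbers for stronger inhibition. Compound 1 `CCN(CC)S(=O)(=O)c1ccc(S(=O)(=O)N2CCC[C@@H](C(=O)NC)C2)cc1` is the smallest of them. In this assay compound 1 reports only the assay limit, > 10000 nM. Compound 2 `CC(C)c1noc(N2CCN(C(=O)[C@@H]3CCCN(S(=O)(=O)c4ccc(S(=O)(=O)C5CCC5)cc4)C3)CC2)n1` carries the larger amide and a cyclobutylsulfonyl group. In this assay compound 2 likewise gives only the limit, > 10000 nM. Compound 3 `CCN(CC)C(=O)c1ccc(S(=O)(=O)N2CCC[C@@H](C(=O)N3CCN(c4nc(C(C)C)no4)CC3)C2)cc1` differs from compound 2 by diethylcarbamoyl in place of cyclobutylsulfonyl on an aromatic carbon, and that step, a step that the two limits leave unreadable from compound 2 to compound 3, cannot be read: both of its ends sit at the limit of > 10000 nM in this assay, at which 3 of the 3 values shown sit. Compound 3 therefore stands at the limit of this assay, > 10000 nM, with no number of its own.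

Compound 4 `CC(C)NS(=O)(=O)c1ccc(S(=O)(=O)N2CCC[C@@H](C(=O)N3CCN(c4nc(C(C)C)no4)CC3)C2)cc1` arises from compound 3 by a single change: isopropylsulfamoyl in place of diethylcarbamoyl on an aromatic carbon. Among the measured compounds shown here, no measured step bears on this change with a readable size; the only step touching compound 3, a step that the two limits leave unreadable from compound 2 to compound 3, is unreadable, and every value in the set rests at the limit of > 10000 nM in this assay, at which 3 of the 3 values shown sit. The data thus support no expectation of a step in either direction beyond the scatter, and the most likely outcome is another limit. Compound 4 is accordingly expected to give about 20000 nM in this assay, within a range of 5000 nM to 100000 nM. The estimated step is a step that the limit leaves unreadable from compound 3 to compound 4.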

Compound 4, half-maximal inhibitory concentration: > 10000 nM
Compound 4: no number, only a limit; the forecaster's own chance of this, stated with the estimate: 85%; the middle value does not contradict the limit.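

In this assay compound 4 gives > 10000 nM, which is a limit and not a number. The steps from compound 2 and compound 3 to compound 4 therefore cannot be read, and all four compounds share one result: the limit of > 10000 nM in this assay, at which 4 of the 4 values shown sit. The compounds shown leave open whether any of these groups on the shared core differs from another in this read-out.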